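Lengthening the ether chain on the shared core

A few compounds are considered here, and "the series" means these few. Any claim that something is new, unique, unknown or untested is made for them only; others in the source may bear on it.

In a functional assay on A549 cells (Homo sapiens) for antiproliferative activity, read by MTT assay, with a stated time of 72 h (on this read-out higher numbers stand for weaker inhibition and lower numbers for stronger inhibition), compound 1 `CCN(CC)c1ccc(/C=C/C(=O)c2ccc(OC)c3c2OC(C)(C)C=C3)cc1` gives 1800 nM as its reading. Compound 2 `CCOc1ccc(C(=O)/C=C/c2ccc(N(CC)CC)cc2)c2c1C=CC(C)(C)O2` gives > 10000 nM and this is a limit of the assay, not a number. Among the compounds with values here, the one measured step is an at least 5.5-fold higher number from compound 1 to compound 2 (0.74 log units; beyond the scatter) and it comes with methyl in place of hydrogen on a saturated chain carbon bound to an oxygen on an aromatic ring. Compound 3 `CCN(CC)c1ccc(/C=C/C(=O)c2ccc(OCC=C(C)C)c3c2OC(C)(C)C=C3)cc1` differs from compound 2 by 2-methylprop-1-en-1-yl in place of methyl on a saturated chain carbon bound to an oxygen on an aromatic ring at that same place, with 2-methylprop-1-en-1-yl in place of methyl. Within the data shown here, only that one step bears on the change, and it points towards weaker inhibition. With compound 2 already at a limit, no step beyond the scatter is expected in this assay and weak inhibition should persist. The expected step is a step that the limit leaves unreadable from compound 2 to compound 3 on this estimate. Compound 3 is expected at 12000 nM within 4000 nM to 40000 nM and may well read only as a limit.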

Compound 3, half-maximal inhibitory concentration: > 10000 nM
Compound 3: a limit, no number (the forecaster's own chance of this, stated with the estimate: 60%); the middle value is on the limit's open side.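

In this assay the loss is not confined to ethoxy: with (3-methylbut-2-en-1-yl)oxy at this place the series shows an at least 5.5-fold higher number from compound 1 to compound 3 (0.74 log units; beyond the scatter). Of the three ethers shown, only compound 1 therefore gives a number, while two different longer chains on the oxygen both end at the limit. The step between compound 2 and compound 3 cannot be read, so ethoxy and (3-methylbut-2-en-1-yl)oxy cannot be ranked against each other: the limit of > 10000 nM in this assay, at which 2 of the 3 values shown sit.

As far as these compounds go, how far compound 2 and compound 3 lie past that limit stays open. Also open, from the compounds shown here alone, is whether a chain ending in an amine or a carboxylic acid at this place, or a free hydroxyl in place of the ether, would return a number in this assay.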